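Propyl in place of cyclopropyl, tested a second time

This account rests on a few compounds, and the source may have more. Where it says the series, first, only, none or still open, it means among the compounds named here.

Measured so far, in an assay on membranes from HeLa cells for displacement of a labelled ligand from adenosine receptor A3 (Homo sapiens), read by scintillation counting, with a stated time of 180 min, tested at 1 uM; a higher number here means more inhibition at the concentration tested (going by the name of the read-out), a lower number less inhibition:
compound 1 `CC1=C(C(=O)C2CC2)C(c2ccoc2)NC(=O)N1`: 16%
compound 2 `CCCC(=O)C1=C(C)NC(=O)NC1c1ccoc1`: 2%
compound 3 `CC1=C(C(=O)C2CC2)C(c2cccs2)NC(=O)N1`: 15%

The change propyl in place of cyclopropyl on a carbonyl carbon made the step of a number 14 percentage points lower from compound 1 to compound 2 (beyond the scatter). The cores of compound 1 and compound 3 differ by thiophen-2-yl in place of furan-3-yl on a saturated ring carbon, and that step, a number 1 percentage points lower from compound 1 to compound 3 (within the scatter), lies within the scatter, so both cores carry the cyclopropylcarbonyl group at a similar level in this assay.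

Compound 4 `CCCC(=O)C1=C(C)NC(=O)NC1c1cccs1` is not yet measured. Relative to compound 3 it carries propyl in place of cyclopropyl on a carbonyl carbon, and the place reads word for word as for compound 2, so this is the same change on the other core. A step of the size of a number 14 percentage points lower from compound 1 to compound 2 (beyond the scatter) is expected again, because compound 3 starts from 15%, close to compound 1; the estimated step is a number 12 percentage points lower from compound 3 to compound 4 (beyond the scatter). Compound 4 is estimated at 3%, within -5% to 12%.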

Compound 4, a percentage reported as inhibition, at one concentration (the size of the read-out at that concentration, not a potency): 2%
The estimate for compound 4 lay 1 percentage points above the measured number; low and high end bracket the measured number.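

In this assay, propyl in place of cyclopropyl on a carbonyl carbon gives a number 13 percentage points lower from compound 3 to compound 4 (beyond the scatter) on the thiophen-2-yl side, matching the step on the core of compound 1: the same change on two cores in this assay, a number 14 percentage points lower (beyond the scatter) from compound 1 to compound 2 and a number 13 percentage points lower (beyond the scatter) from compound 3 to compound 4, 1 percentage points apart, within the scatter of two such steps

With propyl in place, thiophen-2-yl in place of furan-3-yl gives no change at the digits printed from compound 2 to compound 4 (within the scatter) and this agrees with the same exchange made with cyclopropyl: the same change on two cores in this assay, a number 1 percentage points lower (within the scatter) from compound 1 to compound 3 and no change at the digits printed (within the scatter) from compound 2 to compound 4, 1 percentage points apart, within the scatter of two such steps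

The two changes therefore read as independent of each other across these four compounds, but this rests on two pairs of steps at a single concentration and shows neither a potency nor any transfer to a third core.

Open, going by these compounds, is whether a longer chain such as butyl, or a branched one such as isopropyl, on the carbonyl carbon follows cyclopropyl or propyl. Also open, on these data alone, is whether phenyl on the saturated ring carbon matches furan-3-yl and thiophen-2-yl.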